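Replacing the 2-chlorophenyl group of compound 2

The source may hold more compounds than are shown below. What is called first, only, known or untested is meant among the compounds shown, and "the series" means these compounds.

Measured in an ADME assay on HepG2 cells (Homo sapiens) for cytotoxicity, read by luminescence, with a stated time of 72 h; a lower number here means that less compound is needed, a higher number that more compound is needed for the effect:
- compound 1 `CCOC(=O)c1c(-c2cccc(Oc3ccccc3)c2)[nH]c2cc(OC)c(F)cc2c1=O`: > 21500 nM (a limit, not a number)
- compound 2 `CCOC(=O)c1c(-c2cccc(-c3ccccc3Cl)c2)[nH]c2cc(OC)c(F)cc2c1=O`: > 21500 nM (a limit, not a number)

Compound 2 has no exact value, only the limit of > 21500 nM. Both measured compounds share this position: the limit of > 21500 nM in this assay, at which 2 of the 2 values shown sit. The next compound, compound 3 `CCOC(=O)c1c(-c2cccc(Cc3nc(C)c(C)s3)c2)[nH]c2cc(OC)c(F)cc2c1=O`, carries this change: a group of 8 heavy atoms (6 carbon, 1 nitrogen, 1 sulfur; one five-membered aromatic ring with 2 hetero atoms) in place of a group of 7 heavy atoms (6 carbon, 1 chlorine; one six-membered aromatic ring of carbon only), on an aromatic carbon. Among the measured compounds shown here, the one measured step that bears on it is a step that the two limits leave unreadable from compound 1 to compound 2. It offers no size to carry over. Given the limit of > 21500 nM for compound 2, no step beyond the scatter is expected in this assay. The estimate amounts to an expected step that the limit leaves unreadable from compound 2 to compound 3. For compound 3 the estimated value is 22000 nM, with an expected range from 9000 nM to 45000 nM.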

Compound 3, half-maximal effective concentration: > 21500 nM
Compound 3 ended at the assay's limit (the forecaster's own chance of this, stated with the estimate: 80%); the middle value does not contradict the limit.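

The steps among compound 1, compound 2 and compound 3 cannot be read, since all three give a limit, not a number, in this assay: the limit of > 21500 nM in this assay, at which 3 of the 3 values shown sit. As far as these compounds go, how far these three compounds truly differ in this assay, and at what concentration any of them would reach the effect, stays open.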